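The compounds below may be only part of what the source reports. "The series", "measured", "known", "first", "only" and "open" are said of these compounds alone.

In a functional assay on A549 cells (Homo sapiens) for antiproliferative activity, read by MTT assay, with a stated time of 72 h (on this read-out higher numbers stand for weaker inhibition and lower numbers for stronger inhibition), compound 1 (`O=S1(=O)C=Cc2ccc(Nc3cccc(C(F)(F)F)c3)cc21`) gives 1440 nM and compound 2 (`O=S1(=O)C=Cc2ccc(Nc3ccc(C(F)(F)F)cc3)cc21`) gives 1140 nM on the same read-out. These two numbers lie within the usual scatter of repeated measurements, so compound 2 stands level with compound 1 and the pair cannot be ranked. Compound 3 (`COc1ccc(Nc2ccc3c(c2)S(=O)(=O)C=C3)cc1`) has not been measured yet. It differs from compound 2 by methoxy in place of trifluoromethyl on an aromatic carbon, para to a large group (methoxy in place of trifluoromethyl on an aromatic carbon). Within the data shown here, no measured pair here shows what such an exchange does in this assay and the data give no direct guide to its size or direction. The closest reference is compound 2 at 1140 nM in the same test, so no change beyond the scatter is expected, with neither direction clearly favoured. The estimated change is small, a 1.1-fold lower number from compound 2 to compound 3 (0.06 log units; within the scatter) by this reckoning, although a real shift either way remains possible. For compound 3 the expected value is 1000 nM with an estimated range from 350 nM to 3000 nM as the span of likely results.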

Compound 3, half-maximal inhibitory concentration: 1220 nM
The estimate for compound 3 lay 1.2-fold (0.09 log units) below the measured number; low and high end bracket the measured number.
By their numbers in this assay, from the lowest: compounds 2, 3 and 1 (each within the scatter of the next).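

In this assay, the step of a 1.1-fold higher number from compound 2 to compound 3 (0.03 log units; within the scatter) comes from putting methoxy in place of trifluoromethyl on an aromatic carbon, para to a large group. Among these compounds, this is the first measured exchange of one group for another at this position, and it leaves compound 3 level with compound 2, even though a group of 4 heavy atoms with 0 hydrogen-bond acceptors gives way to one of 2 heavy atoms with 1 hydrogen-bond acceptor. At this position, then, the read-out does not separate these two groups, and nothing available explains why they stand level.

Going by these compounds, whether a different kind of group at this position, such as an amine, a carboxylic acid or a longer chain like ethoxy, would move the number beyond the usual scatter remains open, as does the result with a plain hydrogen there. Also open, on these data alone, is how methoxy would behave in the place that trifluoromethyl holds in compound 1, and whether the level result found here would carry over to that position.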